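Swapping the aryl group on the amine of compound 1

The compounds below may be only part of what the source reports. "The series", "measured", "known", "first", "only" and "open" are said of these compounds alone.

Compound 1, `Cc1ccc(NC2=CC(=O)c3nc4n(c3C2=O)[C@H]2OC[C@@H](O)[C@H]2OC4)cc1C`, is the starting point of this account. In a functional assay on HeLa cells (Homo sapiens) for inhibition, read by sulforhodamine B assay (on this read-out higher numbers stand for weaker inhibition and lower numbers for stronger inhibition), compound 1 gives 2690 nM, the lowest of the two numbers recorded there. Its nearest neighbour is compound 2, `CCCc1ccc(NC2=CC(=O)c3c(nc4n3[C@H]3OC[C@@H](O)[C@H]3OC4)C2=O)cc1`, which in this assay gives 6030 nM. Compound 3, `O=C1C(NC2CC2)=CC(=O)c2c1nc1n2[C@H]2OC[C@@H](O)[C@H]2OC1`, is recorded in this assay only as a limit, > 16000 nM; (the limit of > 16000 nM in this assay, at which 1 of the 3 values shown sits). Going by the values given here, the one measured step, an at least 2.6-fold higher number from compound 2 to compound 3 (0.42 log units; beyond the scatter), shows that removing the aryl group from the amine nitrogen weakens inhibition at least modestly.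

The step from compound 1 to compound 4, `CCCc1ccc(NC2=CC(=O)c3nc4n(c3C2=O)[C@H]2OC[C@@H](O)[C@H]2OC4)cc1`, is 4-propylphenyl in place of 3,4-dimethylphenyl on an amine nitrogen. Among the compounds with values here, no measured pair isolates this exact change. Compound 2 carries the same 4-propylphenyl on an amine nitrogen, though on a core arranged differently from that of compound 1, and its value sits beyond the scatter above that of compound 1. The author therefore expects compound 4 to sit between the two, with a modest weakening estimated as a 1.7-fold higher number from compound 1 to compound 4 (0.22 log units; within the scatter). In this assay, within the data shown here, compound 4 is expected to give about 4500 nM, with a range from 1800 nM to 11000 nM, the uncertainty reflecting that the only guide is an analogue on a differently arranged core.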

Compound 4, half-maximal inhibitory concentration: 4990 nM
For compound 4 the middle estimate is 1.1-fold (0.04 log units) below the measured one, within the range that was stated.
By their numbers in this assay, from the lowest: compounds 1, 4 and 2 (each within the scatter of the next, the first and the last beyond it). At a limit, above all of these: compound 3.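

Putting 4-propylphenyl in place of 3,4-dimethylphenyl on an amine nitrogen gives a 1.9-fold higher number from compound 1 to compound 4 (0.27 log units; within the scatter) in this assay. The earlier step concerned the replacement of an aryl group by cyclopropyl, whereas this pair keeps an aryl group on that nitrogen and shows, on the core of compound 1, that two differently substituted phenyl groups can be exchanged with their numbers remaining within the scatter of each other. The data shown give no measured property that would explain how this pair compares, and the one available observation, a limit recorded for a different compound, does not bear on this change.

Going by these compounds alone, it remains open how cyclopropyl on the amine nitrogen would read on the core of compound 1, since the only comparison with that group lies on the differently arranged core of compound 2. Also open, from the compounds shown here alone, is how far this tolerance extends: a phenyl ring carrying a carboxylic acid or an amine, or a longer chain such as hexyl in place of propyl, could still separate from compound 1 in this assay.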